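The source may hold more compounds than are shown below. What is called first, only, known or untested is meant among the compounds shown, and "the series" means these compounds.

Compound 2 `CN(c1ccc2[nH]c(-c3n[nH]c4ccccc34)cc2n1)S(=O)(=O)c1ccc(Cl)cc1` carries a (4-chlorophenyl)sulfonyl on the ring nitrogen where compound 1 `CN(C(=O)c1ccc(Cl)cc1)c1ccc2[nH]c(-c3n[nH]c4ccccc34)cc2n1` carries a (4-chlorophenyl)carbonyl. In a functional assay on KB cells (Homo sapiens) for antiproliferative activity, read by MTT assay, with a stated time of 72 h (on this read-out higher numbers stand for weaker inhibition and lower numbers for stronger inhibition), compound 1 gives 630 nM, and compound 2 gives 8350 nM; the exchange of carbonyl for sulfonyl gave a 13-fold higher number from compound 1 to compound 2 (1.12 log units; beyond the scatter). Among the compounds with values here, compound 2 thus holds the highest number of the two measured so far, with compound 1 as its only neighbour. Compound 3 `CN(c1ccc2[nH]c(-c3n[nH]c4ccccc34)cc2n1)S(=O)(=O)c1ccc(Br)cc1` differs from compound 2 in one place: bromo in place of chloro on an aromatic carbon. Within the data shown here, no measured step concerns this exchange; the only step known, from carbonyl to sulfonyl, concerns a different part of the molecule and offers no guide to a halogen swap on the aryl ring. The expected step is a 1.0-fold lower number from compound 2 to compound 3 (0.02 log units; within the scatter), none beyond the scatter. Compound 3 is expected to give 8000 nM in this assay, within a range from 4000 nM to 16000 nM.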

Compound 3, half-maximal inhibitory concentration: 7150 nM
Compound 3: middle estimate off by 1.1-fold (0.05 log units), on the high side, within the range that was stated.
By their numbers in this assay, from the lowest: compound 1; then compounds 3 and 2 (each within the scatter of the next).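

With the sulfonyl linker in place, bromo in place of chloro on the aromatic carbon gives a 1.2-fold lower number from compound 2 to compound 3 (0.07 log units; within the scatter) in this assay, so this halogen exchange does not separate the two sulfonyl compounds. The distance from the carbonyl compound remains with either halogen: an 11-fold higher number from compound 1 to compound 3 (1.05 log units; beyond the scatter) stands alongside a 13-fold higher number from compound 1 to compound 2 (1.12 log units; beyond the scatter) as a large step, and compound 2 and compound 3 both lie far from compound 1 on this read-out. No supporting data bear on why the halogen exchange leaves the number within the scatter.

As far as these compounds go, whether a group of another kind at this place on the ring, such as an amine, a carboxylic acid or a methoxy, would move the number beyond the scatter remains open. Also open, from the compounds shown here alone, is whether bromo in place of chloro behaves alike on the carbonyl side of the series.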